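The compounds below may be only part of what the source reports. "The series", "measured", "known", "first", "only" and "open" are said of these compounds alone.

The series shares the core of compound 1 `CCCn1c(=O)[nH]c2nc(-c3ccc(S(=O)(=O)N4CCN(c5cccc(Cl)c5)CC4)cc3)[nH]c2c1=O`. In an assay on CHO cells for displacement of a labelled ligand from adenosine receptor A1 (Homo sapiens), read by scintillation counting, with a stated time of 90 min, in the presence of a further agent that is not named here (on this read-out higher numbers stand for weaker inhibition and lower numbers for stronger inhibition), compound 1 gives > 1000 nM, which is a limit of the assay rather than a number. Compound 2 `CCCn1c(=O)c2[nH]c(-c3ccc(S(=O)(=O)N4CCN(c5ccc(Cl)cc5)CC4)cc3)nc2n(C)c1=O` is the other measured member. In this assay compound 2 gives > 1000 nM, again a limit. Both measured values sit at the same limit (the limit of > 1000 nM in this assay, at which 2 of the 2 values shown sit), so compound 1 cannot be ranked against compound 2; the two values show only that neither reaches measurable inhibition in this assay.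

Compound 3 `CCCn1c(=O)[nH]c2nc(-c3ccc(S(=O)(=O)N4CCN(Cc5ccc(Br)cc5)CC4)cc3)[nH]c2c1=O` has not yet been measured. Relative to compound 1 the change is 4-bromobenzyl in place of 3-chlorophenyl on an amine nitrogen in a ring. Among the measured compounds shown here, no step between measured compounds is available, so the expectation for compound 3 rests on the structural change and on the two limits alone. With both measured values at the limit, the step that the limit leaves unreadable from compound 1 to compound 3 is expected to be small, within the scatter or at most a modest move, and compound 3 is expected to stay in the weak range. Compound 3 is estimated at 2000 nM, within the range 500 nM to 8000 nM, with a fair chance that this assay again reports only a limit.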

Compound 3, inhibition constant: > 1000 nM
Compound 3: only a limit was reported; the forecaster's own chance of this, stated with the estimate: 65%; the middle value does not contradict the limit.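

In this assay compound 3 gives > 1000 nM as a limit of the assay. Among the compounds shown here, no step from compound 1 to compound 3 can be read, since every value shown sits at the same limit: the limit of > 1000 nM in this assay, at which 3 of the 3 values shown sit. The compounds shown leave open how far each lies from that limit and which change to the shared core would give measurable inhibition.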